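Swapping tert-butyl for phenyl at a position where the numbers are low

A few compounds are considered here, and "the series" means these few. Any claim that something is new, unique, unknown or untested is made for them only; others in the source may bear on it.

Measured compounds:
compound 1 `COCCNc1nc(C)cc2c1c(N)nn2C`, 6%
compound 2 `Cc1cc2nn(-c3ccccc3)c(N)c2c(=O)[nH]1`, 5%
compound 3 `CC(C)(C)c1cc2nn(-c3ccccc3)c(N)c2c(=O)[nH]1`, 7%

Of the compounds shown here, three have been tested in an assay on isolated protein for inhibition of RAC-alpha serine/threonine-protein kinase (Homo sapiens), read by mobility shift assay, tested at 30 uM; on this read-out lower numbers stand for less inhibition and higher numbers for more inhibition at the one concentration tested (going by the name of the read-out). Compound 1 `COCCNc1nc(C)cc2c1c(N)nn2C` gives 6%, compound 2 `Cc1cc2nn(-c3ccccc3)c(N)c2c(=O)[nH]1` gives 5%, and compound 3 `CC(C)(C)c1cc2nn(-c3ccccc3)c(N)c2c(=O)[nH]1` gives 7%. Compound 3 shows the largest of the three numbers, but its gaps to compound 1 and to compound 2 both lie within the scatter, so no order among them can be read.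

Among the compounds with values here, the one measured step, tert-butyl in place of methyl on an aromatic carbon, gave a number 2 percentage points higher from compound 2 to compound 3 (within the scatter), a change within the scatter.

Compound 4 `Nc1c2c(=O)[nH]c(-c3ccccc3)cc2nn1-c1ccccc1` has not yet been measured. It differs from compound 3 by phenyl in place of tert-butyl on an aromatic carbon. Within the data shown here, the only step that bears on this is the one from compound 2 to compound 3, where a change of the group on the same aromatic carbon left the read-out essentially flat. With all three numbers so low and no step beyond the scatter, compound 4 is expected to show no change at the digits printed from compound 3 to compound 4 (within the scatter), that is, no step beyond the scatter. The estimate for compound 4 in this assay is 7%, with a range from 0% to 18%.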

Compound 4, a percentage reported as inhibition, at one concentration (the size of the read-out at that concentration, not a potency): -2%
Beside the measured number, compound 4's estimate is 9 percentage points above it; the whole stated range lies above it.
By their numbers in this assay, from the lowest: compounds 4, 2, 1 and 3 (each within the scatter of the next).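

Within the data shown here, replacing tert-butyl with phenyl on this aromatic carbon, next to the ring nitrogen, gave a number 9 percentage points lower from compound 3 to compound 4 (within the scatter) in this assay and is the first change here that places a ring at this position. Measured against the smaller methyl group, phenyl gave a number 7 percentage points lower from compound 2 to compound 4 (within the scatter) and so also stays inside the usual variation, which means that methyl, tert-butyl and phenyl cannot be told apart at this position in this read-out. No measurement shown here offers an explanation for this flat result.

The compounds leave open whether any group on this carbon can lift inhibition clear of the scatter, since methyl, tert-butyl and phenyl all give low numbers and none of them serves as a reference for a real gain or loss. As far as these compounds go, an amine, a carboxylic acid or a longer chain at this position would test that, and it also remains open whether the flat result holds when the phenyl on the ring nitrogen of the shared core is replaced by another group.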